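This account rests on a few compounds, and the source may have more. Where it says the series, first, only, none or still open, it means among the compounds named here.

Compound 1 `COc1cc(/C=C/C(=O)c2cccc(-n3cc(-c4ccccc4)[nH]c3=O)c2)ccc1O` is examined in a functional assay on HOP-92 cells (Homo sapiens) for inhibition (on this read-out higher numbers stand for weaker inhibition of growth and lower numbers for stronger inhibition of growth), where compound 1 gives 2270 nM. Among the three compounds with known numbers it carries the lowest one, though compound 3 `COc1ccc(-c2cn(-c3cccc(C(=O)/C=C/c4ccc(O)c(OC)c4)c3)c(=O)[nH]2)cc1` with 2960 nM lies within the scatter of it, while compound 2 `COc1ccc(-c2cn(-c3cccc(C(=O)/C=C/c4cc(OC)c(OC)c(OC)c4)c3)c(=O)[nH]2)cc1` with 14900 nM lies well apart. The step of a 1.3-fold higher number from compound 1 to compound 3 (0.12 log units; within the scatter) changes the phenyl on the core and not the chain, and it leaves the number essentially where it was. Going by the values given here, the step of a 5.0-fold lower number from compound 2 to compound 3 (0.70 log units; beyond the scatter) changes the aryl group on the chain and is the only measured step that touches that place.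

Compound 4 `O=C(/C=C/c1cccc(O)c1)c1cccc(-n2cc(-c3ccccc3)[nH]c2=O)c1` differs from compound 1 at that same place: 3-hydroxyphenyl in place of 4-hydroxy-3-methoxyphenyl on a double-bonded chain carbon bound to a double-bonded chain carbon. The step from compound 2 to compound 3 shows that exchanging the aryl on the chain can shift the number by a modest amount; it does not, however, test the particular exchange made here, since the 4-hydroxy-3-methoxyphenyl is kept in both compound 1 and compound 3. Among the compounds with values here, with one bearing step of modest size and no direct precedent, a modest weakening or no change beyond the scatter is expected. Compound 4 is therefore estimated to give 3500 nM, between 1400 nM and 9000 nM, which corresponds to an expected step of a 1.5-fold higher number from compound 1 to compound 4 (0.19 log units; within the scatter).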

Compound 4, concentration for 50% growth inhibition: 5040 nM
Compound 4: the middle estimate sits 1.4-fold (0.16 log units) below what was measured, within the range that was stated.
By their numbers in this assay, from the lowest: compounds 1, 3 and 4 (each within the scatter of the next, the first and the last beyond it); then compound 2.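

In this assay, going by these compounds alone, a 2.2-fold higher number from compound 1 to compound 4 (0.35 log units; beyond the scatter) gives the first measured exchange on the chain aryl in a compound with the unsubstituted phenyl on the core, and, unlike a 1.3-fold higher number from compound 1 to compound 3 (0.12 log units; within the scatter), this step lies beyond the scatter. Together with a 5.0-fold lower number from compound 2 to compound 3 (0.70 log units; beyond the scatter), it means that in both pairs that differ at this place, the compound with 4-hydroxy-3-methoxyphenyl has the lower number, and no compound shown goes against this, although the comparison rests on only two pairs with different partner groups. This change is also smaller in effect than the earlier step away from 3,4,5-trimethoxyphenyl only in the sense that its printed step is the smaller of the two, and no evidence bearing on the reason for either step is available.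

The compounds shown leave open how much of the step belongs to the loss of the methoxy and how much to the different hydroxy placement, since 3-hydroxyphenyl and 4-hydroxy-3-methoxyphenyl differ in both respects and no compound here separates them. They also leave open how a 4-hydroxyphenyl, or an aryl carrying an amine or a carboxylic acid, would read at this place on the chain.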